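The compounds below may be only part of what the source reports. "The series", "measured", "known", "first", "only" and "open" are said of these compounds alone.

Of the compounds shown here, three have been measured so far, all sharing one core in which a long chain sits on a tetrazole-type ring and an amide links the core to an aromatic group on the carbonyl carbon. Compound 1 `CCCCCCCCCCCCn1nnc(C(NC(=O)c2c(C(C)C)cccc2C(C)C)c2ccccc2)n1` gives 810 nM in an assay on microsomes from liver for inhibition of sterol O-acyltransferase 1 (Rattus norvegicus); a lower number here means a stronger inhibitor, a higher number a weaker inhibitor. Compound 2 `CCCCCCCCCCCCn1nnc(C(NC(=O)c2c(C)cccc2C)c2ccccc2)n1` gives 310 nM in this assay. Compound 3 `CCCCCCCCCCCCn1nnc(C(NC(=O)c2ccc(F)cc2F)c2ccccc2)n1` gives 490 nM in this assay. Among these three numbers compound 3 stands second highest; the steps of a 1.6-fold higher number from compound 2 to compound 3 (0.20 log units; within the scatter) and a 1.7-fold lower number from compound 1 to compound 3 (0.22 log units; within the scatter) both lie within the usual scatter. Among the compounds with values here, only the step of a 2.6-fold lower number from compound 1 to compound 2 (0.42 log units; beyond the scatter) reaches beyond the scatter, and even that is modest.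

Compound 4 `CCCCCCCCCCCCn1nnc(C(NC(=O)c2ccccc2)c2ccccc2)n1` is the next compound, and it differs from compound 3 in one place: phenyl in place of 2,4-difluorophenyl on a carbonyl carbon. Every measured step here has swapped the aromatic group on the carbonyl carbon, and none has shifted the number by much. The change from compound 3 to compound 4 is of the same kind, so the expected step of a 1.0-fold higher number from compound 3 to compound 4 (0.01 log units; within the scatter) should stay within the scatter, with no clear direction. Compound 4 is therefore expected to give about 500 nM in this assay, with a likely range from 200 nM to 1300 nM.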

Compound 4, half-maximal inhibitory concentration: 350 nM
Beside the measured number, compound 4's estimate is 1.4-fold (0.15 log units) above it; the measured number falls inside the stated range.
By their numbers in this assay, from the lowest: compounds 2, 4, 3 and 1 (each within the scatter of the next, the first and the last beyond it).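

In this assay compound 4 carries a plain phenyl with no substituent, yet a 1.4-fold lower number from compound 3 to compound 4 (0.15 log units; within the scatter) and a 1.1-fold higher number from compound 2 to compound 4 (0.05 log units; within the scatter) both stay within the scatter, so on this carbonyl carbon neither 2,4-difluorophenyl nor 2,6-dimethylphenyl is needed to keep the number at this level. The step of a 2.3-fold lower number from compound 1 to compound 4 (0.36 log units; beyond the scatter) is only the second one here to pass beyond the scatter, it is still modest, and like the first it involves leaving 2,6-diisopropylphenyl. Compound 3 goes against any clean split of that group from the others, with its value lying within the scatter of compound 1 as well as of compound 4.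

Nothing in the data at hand explains why these aromatic groups give such close numbers. Also open, as far as these compounds go, is whether an amine or a carboxylic acid on the phenyl of compound 4, or a shorter chain in place of the long chain on the shared core, would move the number further than these aromatic swaps have.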